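From Compound 2 to Compound 3: One Small Change

A few compounds are considered here, and "the series" means these few. Any claim that something is new, unique, unknown or untested is made for them only; others in the source may bear on it.

Compound 1 `O=c1cc(N2CCN(CC3CCCCC3)CC2)sc2c(NO)cc(C(F)(F)F)cc12` and compound 2 `Cc1ccc(C(=O)OC2CCC(CN3CCN(c4cc(=O)c5cc(C(F)(F)F)cc([N+](=O)[O-])c5s4)CC3)CC2)cc1` were both tested in an ADME assay on cells (Hepatocyte, Mus musculus) for metabolic stability, with a stated time of 30 min; a lower number here means that less of the compound is left, a higher number that more of the compound is left. Compound 1 gives 47.8%, while compound 2 gives 18%, the lower of the two numbers by a margin beyond the usual scatter. Compound 3 `COc1ccc(C(=O)OC2CCC(CN3CCN(c4cc(=O)c5cc(C(F)(F)F)cc([N+](=O)[O-])c5s4)CC3)CC2)cc1` has not yet been measured. It differs from compound 2 in one place: methoxy in place of methyl on an aromatic carbon. For the measured compounds named here, no measured pair shows this same change, so the expected step in this assay is small and within the scatter, with no clear direction. Compound 3 is estimated at 16%, with a range from 6% to 30%, an expected step of a number 2 percentage points lower from compound 2 to compound 3 (within the scatter).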

Compound 3, percent of the compound remaining: 31%
Estimate against measurement, compound 3: 15 percentage points below, and the stated range ends below it.
By their numbers in this assay, from the lowest: compound 2; then compound 3; then compound 1.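

Methoxy in place of methyl on this aromatic carbon, para to a large group, gives a number 13 percentage points higher from compound 2 to compound 3 (beyond the scatter) in this assay. So this position is not silent: adding one oxygen here moves the read-out by more than the scatter, the first such single-place step in this set. Nothing at hand says why the number rises.

Going by these compounds, how an amine, a hydroxyl or a longer chain such as ethoxy at this carbon would read stays open. So does whether the same swap gives a similar step on a different core.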